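This account rests on a few compounds, and the source may have more. Where it says the series, first, only, none or still open, it means among the compounds named here.

Compound 1 `C[C@H](NC(=O)C(=O)Nc1ccccn1)C(=O)N[C@@H](CC(=O)O)C(=O)COc1c(F)c(F)cc(F)c1F` gives 200 nM in a functional assay on THP-1 cells (Homo sapiens) for inhibition (a higher number here means a weaker inhibitor, a lower number a stronger inhibitor), and stands second highest of the three numbers seen so far: compound 3 `C[C@H](NC(=O)C(=O)Nc1ccccc1C(F)(F)F)C(=O)N[C@@H](CC(=O)O)C(=O)COc1c(F)c(F)cc(F)c1F` gives 190 nM, within the scatter of it, while compound 2 `C[C@H](NC(=O)C(=O)Nc1ccccc1Cl)C(=O)N[C@@H](CC(=O)O)C(=O)COc1c(F)c(F)cc(F)c1F` gives 540 nM, a clearly higher number. The step to compound 4 `C[C@H](NC(=O)C(=O)Nc1ccccc1-c1ccc[nH]1)C(=O)N[C@@H](CC(=O)O)C(=O)COc1c(F)c(F)cc(F)c1F` is 2-(1H-pyrrol-2-yl)phenyl in place of pyridin-2-yl on an amide-type nitrogen. Within the data shown here, two measured steps bear on it, each also replacing the pyridin-2-yl by a phenyl that carries a group: a 2.7-fold higher number from compound 1 to compound 2 (0.43 log units; beyond the scatter), whereas a 1.1-fold lower number from compound 1 to compound 3 (0.02 log units; within the scatter). Between those two, a 2.8-fold lower number from compound 2 to compound 3 (0.45 log units; beyond the scatter). Since the move to compound 4 likewise swaps the pyridin-2-yl for a phenyl bearing a group, a step in this assay from none up to a modest weakening is expected, written as a 1.5-fold higher number from compound 1 to compound 4 (0.18 log units; within the scatter). Compound 4 is therefore estimated to give 300 nM in this assay, with a range of 120 nM to 800 nM.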

Compound 4, half-maximal inhibitory concentration: > 32000 nM
Compound 4: a limit, no number; the forecaster's own chance of this, stated with the estimate: 5%; at least 100-fold (2.02 log units) between middle value and limit.
By their numbers in this assay, from the lowest: compounds 3 and 1 (each within the scatter of the next); then compound 2. At a limit, above all of these: compound 4.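

In this assay compound 4 gives a limit and not a number: the limit of > 32000 nM in this assay, at which 1 of the 4 values shown sits. The earlier replacements on this phenyl moved the number modestly at most, but 1H-pyrrol-2-yl on the same aromatic carbon brings an at least 59-fold higher number from compound 2 to compound 4 (1.77 log units; beyond the scatter) in place of chloro and an at least 160-fold higher number from compound 3 to compound 4 (2.22 log units; beyond the scatter) in place of trifluoromethyl. Against the pyridin-2-yl on the amide-type nitrogen there is an at least 160-fold higher number from compound 1 to compound 4 (2.20 log units; beyond the scatter), so this place accepts some groups on the phenyl but not this one. The compounds shown leave open whether the hydrogen-bond donor of the pyrrole or the added ring itself matters, and 1-methylpyrrol-2-yl or phenyl on that carbon would separate the two.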